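Working notes: ether variation from compound 3 to compound 4

A few compounds are considered here, and "the series" means these few. Any claim that something is new, unique, unknown or untested is made for them only; others in the source may bear on it.

Measured compounds:
compound 1 `CC1CCN(c2cc(C(F)(F)F)ccc2CNC(=O)C(C)c2ccc(NS(C)(=O)=O)c(F)c2)CC1` — 0.9 nM
compound 2 `CC(C(=O)NCc1ccc(C(F)(F)F)cc1N1CCN(c2ccccc2)CC1)c1ccc(NS(C)(=O)=O)c(F)c1` — 2 nM
compound 3 `CCCOc1cc(C(F)(F)F)ccc1CNC(=O)C(C)c1ccc(NS(C)(=O)=O)c(F)c1` — 2 nM

All three share one core and differ only in the group on the aromatic carbon of the benzylic ring. In an assay on CHO cells for antagonist activity at transient receptor potential cation channel subfamily V member 1 (Homo sapiens), read by FLIPR (on this read-out higher numbers stand for weaker inhibition and lower numbers for stronger inhibition), compound 1 gives 0.9 nM, compound 2 gives 2 nM and compound 3 gives 2 nM. Compound 3 stands level with compound 2, the two together the highest numbers of the set; the step of a 2.2-fold higher number from compound 1 to compound 3 (0.35 log units; beyond the scatter) and the step of a 2.2-fold higher number from compound 1 to compound 2 (0.35 log units; beyond the scatter) are both modest but beyond the scatter, while no change at the digits printed from compound 2 to compound 3 (within the scatter) is within it.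

Compound 4 `CC(C(=O)NCc1ccc(C(F)(F)F)cc1OCc1ccc(F)cc1)c1ccc(NS(C)(=O)=O)c(F)c1` is not yet measured. It differs from compound 3 by 4-fluorophenyl in place of ethyl on a saturated chain carbon bound to an oxygen on an aromatic ring. Among the compounds with values here, no measured step replaces an ethyl by an aryl at such a chain carbon. The nearest guidance is that a propoxy and a phenyl-bearing 4-phenylpiperazin-1-yl come out alike in this assay, no change at the digits printed from compound 2 to compound 3 (within the scatter), which suggests that an added aromatic ring at this site need not move the number much, whereas the 4-methylpiperidin-1-yl of compound 1 gives a somewhat lower number, a 2.2-fold higher number from compound 1 to compound 3 (0.35 log units; beyond the scatter). With only one ether in the set the direction is uncertain. The expected step is no change at the digits printed from compound 3 to compound 4 (within the scatter), that is, no change beyond the scatter. Compound 4 is therefore estimated at 2 nM, with a range from 0.7 nM to 6 nM.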

Compound 4, inhibition constant: 0.5 nM
Compound 4: middle estimate off by 4.0-fold (0.60 log units), on the high side; measured number below the stated range.
By their numbers in this assay, from the lowest: compounds 4 and 1 (each within the scatter of the next); then compounds 2 and 3 (each within the scatter of the next).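

In this assay, 4-fluorophenyl in place of ethyl on a saturated chain carbon bound to an oxygen on an aromatic ring gives a 4.0-fold lower number from compound 3 to compound 4 (0.60 log units; beyond the scatter), the first sign that the ether at this site responds to what its chain carries. An added aromatic ring does not act alike in every group: (4-fluorobenzyl)oxy in place of 4-phenylpiperazin-1-yl gives a 4.0-fold lower number from compound 2 to compound 4 (0.60 log units; beyond the scatter), although the 4-phenylpiperazin-1-yl of compound 2 and the ring-free propoxy of compound 3 print the same number. Against 4-methylpiperidin-1-yl, the same ether gives a 1.8-fold lower number from compound 1 to compound 4 (0.26 log units; within the scatter), so the assay does not separate these two groups, and nothing on hand accounts for any of these steps.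

From the compounds shown here alone, it remains open whether the step belongs to the aromatic ring or to its fluorine, which a plain benzyloxy would address, and whether a nitrile or a chlorine in place of that fluorine would read the same. A longer chain between the oxygen and the ring, as in 2-phenylethoxy, also leaves the tolerated reach of this ether unsettled.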